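A few compounds are considered here, and "the series" means these few. Any claim that something is new, unique, unknown or untested is made for them only; others in the source may bear on it.

- Compound 1 `CC(C)(C)c1ccc(C(CC(=O)O)NC(=O)c2ccc(F)cc2)cc1`: 87600 nM
- Compound 2 `COc1ccc(C(=O)NC(CC(=O)O)c2ccc(C(C)(C)C)cc2)cc1`: > 100000 nM

Both compounds were tested in a functional assay on MDA-MB-231 cells (Homo sapiens) for antiproliferative activity, read by MTT assay, with a stated time of 24 h; a lower number here means a stronger inhibitor, a higher number a weaker inhibitor. Compound 2 has only a limit, > 100000 nM, and not a number. Compound 3 `CC(C)(C)c1ccc(C(CC(=O)O)NC(=O)c2ccc(C(F)(F)F)cc2)cc1` differs from it by trifluoromethyl in place of methoxy on an aromatic carbon, para to a large group. Going by the values given here, no measured step involves trifluoromethyl. Among the compounds with values here, the one step that bears on this position is methoxy in place of fluoro, an at least 1.1-fold higher number from compound 1 to compound 2 (0.05 log units; that floor lies within the scatter). As that floor lies within the scatter, a step beyond the scatter is not expected here in this assay, in either direction. Compound 3 is therefore expected to stay weak, in the region of compound 1 at 87600 nM. For compound 3 the estimate is 90000 nM, with an expected range of 40000 nM to 200000 nM. This estimated step is an at least 1.1-fold lower number from compound 2 to compound 3 (0.04 log units; that floor lies within the scatter).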

Compound 3, half-maximal inhibitory concentration: 78800 nM
For compound 3 the middle estimate is 1.1-fold (0.06 log units) above the measured one; the range from low to high includes it.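

In this assay, compound 3 adds a second measured number for this position, with trifluoromethyl on the aromatic carbon para to a large group. The change from fluoro gives a 1.1-fold lower number from compound 1 to compound 3 (0.05 log units; within the scatter), so these two groups cannot be told apart here, while the change from methoxy gives an at least 1.2-fold lower number from compound 2 to compound 3 (0.10 log units; that floor lies within the scatter). Compound 2 stands at > 100000 nM, a limit and not a number, so this second step can be read only as a floor: the limit of > 100000 nM in this assay, at which 1 of the 3 values shown sits.

As far as these compounds go, whether an amine or a hydroxyl group at this position would move the number beyond the scatter stays open. Also open, from the compounds shown here alone, is whether a change elsewhere on the shared core, such as an ester in place of its carboxylic acid, would do so.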